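A Propyl for Methyl at the Piperazine End

The source may report more compounds than this note shows. Statements on the series, on what has been measured and on what is new or still open speak of the compounds shown alone.

In a functional assay on SH-SY5Y cells (Homo sapiens) for cytotoxicity, read by MTT assay, with a stated time of 72 h (a lower number here means a stronger inhibitor, a higher number a weaker inhibitor), compound 1 (`O=C1c2c[n+]([O-])c3ccccc3c2C(=O)c2c1c1ccccc1n2Cc1cn([C@H]2O[C@H](CO)[C@@H](O)[C@H]2O)nn1`) gives 1340 nM, compound 2 (`CC1(C)OCC(Cn2cc(Cn3c4c(c5ccccc53)C(=O)c3c[n+]([O-])c5ccccc5c3C4=O)nn2)O1`) gives 230 nM, and compound 3 (`CN1CCN(CCCCn2c3c(c4ccccc42)C(=O)c2c[n+]([O-])c4ccccc4c2C3=O)CC1`) gives 100 nM. Compound 3 thus has the lowest of the three numbers, and its gap to each of the other two lies beyond the scatter.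

Compound 4 (`CCCN1CCN(CCCCn2c3c(c4ccccc42)C(=O)c2c[n+]([O-])c4ccccc4c2C3=O)CC1`) differs from compound 3 in one place: ethyl in place of hydrogen on a saturated chain carbon bound to an amine nitrogen in a ring. This is ethyl in place of hydrogen on a saturated chain carbon bound to an amine nitrogen in a ring, so that 4-methylpiperazin-1-yl becomes 4-propylpiperazin-1-yl.

Among the compounds with values here, only one measured step connects two compounds through a single change, a 5.8-fold lower number from compound 1 to compound 2 (0.77 log units; beyond the scatter), with (2,2-dimethyl-1,3-dioxolan-4-yl)methyl in place of 3,4-dihydroxy-5-(hydroxymethyl)oxolan-2-yl on an aromatic nitrogen. That step is a different change at a different place, so it offers only weak guidance. Within the data shown here, no measured step turns methyl into propyl, and the data therefore give no firm direction. A small change in this assay is expected, with no move beyond the scatter. The estimated step is a 1.3-fold higher number from compound 3 to compound 4 (0.11 log units; within the scatter). For compound 4 the estimated value is 130 nM, with an expected range from 50 nM to 320 nM.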

Compound 4, half-maximal inhibitory concentration: 3970 nM
Compound 4: the middle estimate sits 31-fold (1.48 log units) below what was measured; measured number above the stated range.
By their numbers in this assay, from the lowest: compound 3; then compound 2; then compound 1; then compound 4.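

In this assay, the end of the side chain proves far from indifferent: ethyl in place of hydrogen on a saturated chain carbon bound to an amine nitrogen in a ring, turning 4-methylpiperazin-1-yl into 4-propylpiperazin-1-yl, gives a 40-fold higher number from compound 3 to compound 4 (1.60 log units; beyond the scatter). Within the data shown here, the only earlier step concerned a different change at a different place, so this is the first reading at this position, and it shows that an ethyl group bringing no ring, no hydrogen-bond donor or acceptor and no net charge is enough for a large step here. Nothing available accounts for a step of this size.

The compounds shown leave open whether the number climbs gradually or abruptly as the chain on the piperazine grows, a question that 4-ethylpiperazin-1-yl or 4-butylpiperazin-1-yl would address. They also leave open whether any group larger than methyl gives the same result, or whether a 2-hydroxyethyl or a cyclopropyl group at this place would read differently from the propyl chain.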